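Hydrazone aryl swap on the shared core

This account rests on a few compounds, and the source may have more. Where it says the series, first, only, none or still open, it means among the compounds named here.

Three compounds of the series have been run in a functional assay, read by spectrophotometry, with a stated time of 15 min, tested at 20 ug/mL; a lower number here means a weaker effect, a higher number a stronger effect of the compound at the concentration tested. Compound 1 `COC(=O)c1cc(-c2csc(N/N=C/c3cccs3)n2)ccc1OCc1ccccc1` gives 94.3% and stands second highest of the three numbers. Compound 2 `Clc1ccc(-c2csc(N/N=C/c3cccs3)n2)cc1` gives 94.4%, a number within the scatter of compound 1. Compound 3 `Cc1ccc(-c2csc(N/N=C/c3ccc(Cl)cc3Cl)n2)cc1` gives 86%, again within the scatter of compound 1, so the three values show no separation beyond the usual spread.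

Compound 4 `COC(=O)c1cc(-c2csc(N/N=C/c3ccc(Cl)cc3Cl)n2)ccc1OCc1ccccc1` is not yet measured. Compared with compound 1 it carries 2,4-dichlorophenyl in place of thiophen-2-yl on a carbon with a double bond to nitrogen. Compound 3 carries the same dichlorophenyl group and gives 86%, so no step beyond the scatter is expected in this assay from compound 1 to compound 4, perhaps a slight downward drift; the expected step is a number 6.3 percentage points lower from compound 1 to compound 4 (within the scatter). Compound 4 is estimated at 88%, with a range from 78% to 96%.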

Compound 4, a percentage reported as inhibition, at one concentration (the size of the read-out at that concentration, not a potency): 19.2%
Beside the measured number, compound 4's estimate is 68.8 percentage points above it; the whole stated range lies above it.
By their numbers in this assay, from the lowest: compound 4; then compounds 3, 1 and 2 (each within the scatter of the next).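

In this assay, the group on the carbon with a double bond to nitrogen matters strongly on the core of compound 1: 2,4-dichlorophenyl in place of thiophen-2-yl gives a number 75.1 percentage points lower from compound 1 to compound 4 (beyond the scatter). The same group also stands in compound 3, which gives 86%, so the outcome of this swap depends on the rest of the molecule. No measured evidence bears on the reason for the loss.

Still open, going by these compounds, is whether unsubstituted phenyl or pyridin-2-yl at this place would keep the number of compound 1. Also open, on these data alone, is which part of the other aryl group, the methyl ester or the benzyl ether, matters for the loss.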